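The source may report more compounds than this note shows. Statements on the series, on what has been measured and on what is new or still open speak of the compounds shown alone.

Compound 1 `Cn1sc2cc(OCc3cccc(-c4ccc(Cl)c(C(=O)O)c4)c3)ccc2c1=O` is the reference point of this set. In an ADME assay on microsomes from liver (Rattus norvegicus) for metabolic stability, read by LC-MS, with a stated time of 1 h, at 37 degrees C, tested at 4 uM (on this read-out higher numbers stand for a more stable compound and lower numbers for a less stable compound), compound 1 gives 84%. Compound 3 `O=C(O)c1cc(-c2cccc(COc3ccc4c(=O)n(C5CCCC5)sc4c3)c2)cc([N+](=O)[O-])c1` gives 84% in this assay, the same figure as compound 1 at the digits read, and compound 2 `CN(C)C(=O)c1cc(-c2cccc(COc3ccc4c(=O)n(C5CCCC5)sc4c3)c2)ccc1Cl` gives 92%, a number that lies within the usual scatter of both. For the measured compounds named here, no single-point step between these measured compounds is available, so the series gives no direct guide for the change to compound 4.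

Compound 4 `CC(C)CCn1sc2cc(OCc3cccc(-c4ccc(Cl)c(C(=O)O)c4)c3)ccc2c1=O` differs from compound 1 as follows: isobutyl in place of hydrogen on a saturated chain carbon bound to an aromatic nitrogen. Nothing measured here reports what an isobutyl at that position does, so the expectation is a modest downward step, estimated as a number 14 percentage points lower from compound 1 to compound 4 (beyond the scatter), which may well stay within the scatter. Compound 4 is therefore expected to give about 70%, in a range from 45% to 90%.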

Compound 4, percent of the compound remaining: 92%
Beside the measured number, compound 4's estimate is 22 percentage points below it; the whole stated range lies below it.
By their numbers in this assay, from the lowest: compounds 1, 3, 2 and 4 (each within the scatter of the next).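

On a saturated chain carbon bound to an aromatic nitrogen, isobutyl in place of hydrogen gives a number 8 percentage points higher from compound 1 to compound 4 (within the scatter) in this assay. Read the other way, methyl to isopentyl at this place leaves the stability reading within the scatter, which the earlier compounds, lacking any single-point step, could not show. Nothing measured here gives a reason for this reading.

Still open, going by these compounds, is how a chain ending in an amine or a hydroxyl group would read at this place. On these data alone, a longer chain also remains open.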